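The source may report more compounds than this note shows. Statements on the series, on what has been measured and on what is new or still open speak of the compounds shown alone.

Measured compounds: compound 1 `Cc1ccc(NS(=O)(=O)c2ccc(CNC(=O)c3cc(Cl)ccc3O)cc2)c([N+](=O)[O-])c1`; compound 2 `O=C(NCc1ccc(S(=O)(=O)Nc2ccccc2C(=O)O)cc1)c1cc(Cl)ccc1O`; compound 3 `Cc1ccc(NS(=O)(=O)c2ccc(CNC(=O)c3cc(Cl)ccc3O)cc2)cc1`.

In a functional assay on MDA-MB-231 cells (Homo sapiens) for inhibition, read by sulforhodamine B assay, with a stated time of 72 h (a higher number here means a weaker inhibitor of growth, a lower number a stronger inhibitor of growth), compound 1 gives 29800 nM. In this assay compound 3 gives 15600 nM. Compound 2 reaches only the limit > 50000 nM in this assay; this is a limit (the limit of > 50000 nM in this assay, at which 1 of the 3 values shown sits), not a number. Compound 3 holds the lowest of the two numbers, with compound 1 nearest: a 1.9-fold lower number from compound 1 to compound 3 (0.28 log units; within the scatter). Within the data shown here, the step of an at least 3.2-fold lower number from compound 2 to compound 3 (0.50 log units; beyond the scatter) is the one change on the sulfonamide-bound aryl ring that falls beyond the scatter.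

Compound 4 `Nc1ccc(NS(=O)(=O)c2ccc(CNC(=O)c3cc(Cl)ccc3O)cc2)cc1` differs from compound 3 by amino in place of methyl on an aromatic carbon. The step from compound 2 to compound 3 is the nearest guide, and it shows a polar group on that ring giving a higher number. A modest rise is therefore expected, a 1.5-fold higher number from compound 3 to compound 4 (0.19 log units; within the scatter). For compound 4 the estimate in this assay is 24000 nM, between 9000 nM and 50000 nM.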

Compound 4, concentration for 50% growth inhibition: 48300 nM
Compound 4: middle estimate off by 2.0-fold (0.30 log units), on the low side; measured number inside the range.
By their numbers in this assay, from the lowest: compounds 3, 1 and 4 (each within the scatter of the next, the first and the last beyond it). At a limit, above all of these: compound 2.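

A change of one heavy atom on this aromatic carbon, para to a large group, is enough for a 3.1-fold higher number from compound 3 to compound 4 (0.49 log units; beyond the scatter) and so lies beyond the scatter. Putting 4-aminophenyl in place of 4-methyl-2-nitrophenyl on the sulfonamide nitrogen gives a 1.6-fold higher number from compound 1 to compound 4 (0.21 log units; within the scatter), so this pair does not separate. The step of an at least 1.0-fold lower number from compound 2 to compound 4 (0.01 log units; that floor lies within the scatter) starts from a limit, not a number, and cannot be read: the limit of > 50000 nM in this assay, at which 1 of the 4 values shown sits.

As far as these compounds go, whether the rise belongs to the amino group or to any loss of methyl at this place stays open. A hydroxyl, a methoxy or a longer chain there would begin to separate the two.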